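The compounds below may be only part of what the source reports. "The series", "measured", "known", "first", "only" and "open" are said of these compounds alone.

The measured compounds are compound 1 `ClCc1ccccc1Cn1cnc2c(Cl)nc(Cl)nc21` with 1580 nM, compound 2 `ClCc1cccc(Cn2cnc3c(Cl)nc(Cl)nc32)c1` with 6450 nM, and compound 3 `Nc1nc(Cl)c2ncn(Cc3ccccc3CCl)c2n1` with 20000 nM, all in a functional assay on OVCAR-5 cells (Homo sapiens) for cytotoxicity, read by sulforhodamine B assay, with a stated time of 48 h; on this read-out lower numbers stand for stronger inhibition of growth and higher numbers for weaker inhibition of growth.

Compound 1 and compound 2 have the same atoms joined differently; the difference between the two cores is not broken down here. Of the three numbers, compound 1 gives the lowest and compound 2 stands second highest, with compound 3 above it. Compound 3 carries the change amino in place of chloro on an aromatic carbon relative to compound 1, and that change made the step of a 13-fold higher number from compound 1 to compound 3 (1.10 log units; beyond the scatter).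

Compound 4 `Nc1nc(Cl)c2ncn(Cc3cccc(CCl)c3)c2n1` has not yet been measured in this assay. It differs from compound 2 by amino in place of chloro on an aromatic carbon, which is the same change at the same place, so this change occurs twice among these compounds. In this assay compound 4 is expected to show a step of a 6.2-fold higher number from compound 2 to compound 4 (0.79 log units; beyond the scatter), because the earlier instance of the change gave a 13-fold higher number from compound 1 to compound 3 (1.10 log units; beyond the scatter). That expectation rests on a single pair, and compound 3 already lies at a high number. Compound 4 is therefore estimated at 40000 nM, with a range from 15000 nM to 120000 nM.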

Compound 4, concentration for 50% growth inhibition: 11000 nM
The estimate for compound 4 lay 3.6-fold (0.56 log units) above the measured number, and the stated range ends above it.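

In this assay the change amino in place of chloro on an aromatic carbon gave a 1.7-fold higher number from compound 2 to compound 4 (0.23 log units; within the scatter) and so did not repeat the size it had on the core of compound 1. The size of the step therefore differs between the two cores: the same change on two cores in this assay, a 13-fold higher number (1.10 log units; beyond the scatter) from compound 1 to compound 3 and a 1.7-fold higher number (0.23 log units; within the scatter) from compound 2 to compound 4, 7.4-fold (0.87 log units) apart, beyond the scatter of two such steps. A step read on one of these cores was thus a poor guide to the same change on the other, but two pairs do not show why the cores differ, nor how the change would behave on any further core.

The compounds shown leave open whether another group at that aromatic carbon, such as a methylamine, a methoxy group or a hydroxyl group, would give a large step on the core of compound 1 and a small one on the core of compound 2. They also leave open whether the difference between the two steps would hold in any other assay.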